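Swapping the aryl group on a weakly active pyrazole core

This account rests on a few compounds, and the source may have more. Where it says the series, first, only, none or still open, it means among the compounds named here.

Measured compounds:
Compound 1 `Cc1nn(-c2nc(-c3ccc(Cl)c(Cl)c3)c(SC(C)C)s2)c(C(=O)O)c1-c1cncc(C#N)c1`: 20000 nM
Compound 2 `COc1cccc(-c2c(C)nn(-c3nc(-c4ccc(Cl)c(Cl)c4)c(SC(C)C)s3)c2C(=O)O)c1`: 14000 nM

Both compounds share one core and differ only in the aryl group attached to it. In a functional assay on BJAB cells (Homo sapiens) for antiproliferative activity, with a stated time of 4 days (on this read-out lower numbers stand for an effect already at smaller amounts and higher numbers for an effect only at larger amounts of compound), compound 1 gives 20000 nM, and compound 2 gives 14000 nM. Going by the values given here, the single step known so far, a 1.4-fold lower number from compound 1 to compound 2 (0.15 log units; within the scatter), tells that these two numbers cannot be told apart. Compound 2 therefore stands at the lower of the two numbers, but only by a margin that means nothing.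

Compound 3 `CC(=O)Nc1ccc(-c2c(C)nn(-c3nc(-c4ccc(Cl)c(Cl)c4)c(SC(C)C)s3)c2C(=O)O)cc1` is the next member of this series. It differs from compound 2 in one place: 4-acetamidophenyl in place of 3-methoxyphenyl on an aromatic carbon. Among the compounds with values here, only the step from compound 1 to compound 2 bears on this change, and it was within the scatter, so the data give no ground for expecting the new aryl group to move the number in either direction. The expected step of a 1.1-fold higher number from compound 2 to compound 3 (0.03 log units; within the scatter) is therefore none beyond the scatter. For compound 3 the estimate is 15000 nM, with a range from 6000 nM to 40000 nM.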

Compound 3, half-maximal effective concentration: 139000 nM
Estimate against measurement, compound 3: 9.3-fold (0.97 log units) below; measured number outside the range, above it.
By their numbers in this assay, from the lowest: compounds 2 and 1 (each within the scatter of the next); then compound 3.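

This position on the shared core is not indifferent to the aryl group it carries, although the first two compounds gave no sign of that. In this assay, 4-acetamidophenyl gives a 9.9-fold higher number from compound 2 to compound 3 (1.00 log units; beyond the scatter), and against the 5-cyanopyridin-3-yl group it gives a 7.0-fold higher number from compound 1 to compound 3 (0.84 log units; beyond the scatter), so this aryl group moves the read-out in the unfavourable direction, towards effects only at larger amounts of compound. Compared with 3-methoxyphenyl, the entering group has 10 heavy atoms rather than 8 and 1 hydrogen-bond donor rather than 0, but nothing measured here links either difference to the higher number.

Compound 2 and compound 3 differ at once in the substituent and in the place it occupies on the phenyl ring, so the two effects cannot be separated. A 3-acetamidophenyl or a 4-methoxyphenyl group would pull them apart, and a 4-aminophenyl group, which lacks the acetyl part, would show whether the full acetamide is needed for the rise.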